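The source may hold more compounds than are shown below. What is called first, only, known or untested is meant among the compounds shown, and "the series" means these compounds.

Compound 1 `CC1=C(C(=O)Nc2ccc(Br)cc2)C(c2ccc(Cl)cc2Cl)N=C(SCc2ccc(Cl)cc2)N1` and compound 2 `CC1=C(C(=O)Nc2ccc(Br)cc2)C(c2ccc(Cl)cc2Cl)N=C(SCc2ccc(F)cc2)N1` share one core; compound 3 `COc1ccc(C2N=C(SCc3ccc(Cl)cc3)NC(C)=C2C(=O)Nc2ccc(Br)cc2)cc1` and the unmeasured compound 4 `COc1ccc(C2N=C(SCc3ccc(F)cc3)NC(C)=C2C(=O)Nc2ccc(Br)cc2)cc1` share another. The two cores differ as follows: 4-methoxyphenyl in place of 2,4-dichlorophenyl on a saturated ring carbon. Within the first pair the change is fluoro in place of chloro on an aromatic carbon, and the same change is made within the second pair: fluoro in place of chloro on an aromatic carbon.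

In a functional assay on the whole organism (artery, strain albino) with Rattus norvegicus as the target, with a stated time of 240 min, at a dose of 10 mg/kg by the oral route (a lower number here means less inhibition, a higher number more inhibition at the dose given (going by the name of the read-out)), compound 1 gives 32.3%, compound 2 gives 36.4% and compound 3 gives 29.2%. The step of a number 4.1 percentage points higher from compound 1 to compound 2 (within the scatter) and the step of a number 3.1 percentage points lower from compound 1 to compound 3 (within the scatter) are both small.

For compound 4 the step of a number 3.8 percentage points higher from compound 3 to compound 4 (within the scatter) is expected, resting on the same change having given a number 4.1 percentage points higher from compound 1 to compound 2 (within the scatter) and on compound 3 standing at 29.2%. Compound 4 is therefore estimated at 33% in this assay, most likely between 20% and 46%.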

Compound 4, a percentage reported as inhibition, in the whole organism at one dose (the size of the read-out at that dose, not a potency): 22.1%
Estimate against measurement, compound 4: 10.9 percentage points above; low and high end bracket the measured number.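

In this assay, fluoro in place of chloro gives a number 7.1 percentage points lower from compound 3 to compound 4 (within the scatter) on the core of compound 3, and this does not separate from the step on the core of compound 1: the same change on two cores in this assay, a number 4.1 percentage points higher (within the scatter) from compound 1 to compound 2 and a number 7.1 percentage points lower (within the scatter) from compound 3 to compound 4, 11.2 percentage points apart, within the scatter of two such steps.
The core change gives a number 14.3 percentage points lower from compound 2 to compound 4 (beyond the scatter) with fluoro in place, yet this too does not separate from its counterpart with chloro: the same change on two cores in this assay, a number 3.1 percentage points lower (within the scatter) from compound 1 to compound 3 and a number 14.3 percentage points lower (beyond the scatter) from compound 2 to compound 4, 11.2 percentage points apart, within the scatter of two such steps.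
This shows no difference between the two cores for either change, but with a single pair on each side it does not show that a step carries over reliably.

Still open, from the compounds shown here alone, is whether a nitrile or a carboxylic acid in place of the halogen on the benzyl group would give a step beyond the scatter on both cores.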